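The source may report more compounds than this note shows. Statements on the series, on what has been measured and on what is new or still open speak of the compounds shown alone.

Of the compounds shown here, three on a shared core have been measured in an ADME assay on microsomes from liver (Homo sapiens) for metabolic stability, with a stated time of 60 min, tested at 1 uM; a higher number here means that more of the compound is left, a lower number that less of the compound is left. Compound 1 `COc1cc(-c2cnn3cc(OC)c(-c4cnn(C)c4)nc23)ccn1` gives 43%, compound 2 `CNc1nc2c(-c3ccnc(OC)c3)cnn2cc1OC` gives 63%, and compound 3 `COc1cc(-c2cnn3cc(OC)c(C4CCOC4)nc23)ccn1` gives 29%, the lowest of the three numbers. Compound 4 `COc1cc(-c2cnn3cc(OC)c(N(C)C)nc23)ccn1` has not yet been measured. Its change from compound 3 is dimethylamino in place of oxolan-3-yl on an aromatic carbon, so dimethylamino stands in place of oxolan-3-yl on an aromatic carbon.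

The nearest evidence comes from compound 2, which carries methylamino on that carbon. Replacing methylamino with oxolan-3-yl gave a number 34 percentage points lower from compound 2 to compound 3 (beyond the scatter), a large step. Replacing 1-methyl-1H-pyrazol-4-yl with oxolan-3-yl gave a number 14 percentage points lower from compound 1 to compound 3 (beyond the scatter), a modest one, and a number 20 percentage points higher from compound 1 to compound 2 (beyond the scatter) is also modest. Oxolan-3-yl therefore sits lowest in both comparisons, which suggests a rise on leaving it. Dimethylamino itself has no measured precedent, so only part of the large step is expected to carry over.

The estimated change is a number 19 percentage points higher from compound 3 to compound 4 (beyond the scatter). Compound 4 is expected at 48%, with an estimated range of 30% to 66%.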

Compound 4, percent of the compound remaining: 16%
Compound 4: the middle estimate sits 32 percentage points above what was measured, and the stated range ends above it.
By their numbers in this assay, from the lowest: compound 4; then compound 3; then compound 1; then compound 2.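

In this assay, adding one methyl to the nitrogen on this aromatic carbon gives the largest of the new steps (a number 47 percentage points lower from compound 2 to compound 4 (beyond the scatter)), so the number seen with methylamino does not extend to dimethylamino, and these two closely related groups mark the two ends of the series. Dimethylamino also stands below both oxolan-3-yl (a number 13 percentage points lower from compound 3 to compound 4 (beyond the scatter)) and 1-methyl-1H-pyrazol-4-yl (a number 27 percentage points lower from compound 1 to compound 4 (beyond the scatter)), which shows that a nitrogen attached at this carbon does not by itself give a higher number. Nothing available here accounts for these steps.

On these data alone, it remains open whether a larger group on that nitrogen, such as ethylamino, or a cyclic amine such as azetidine or morpholine, would fall near compound 2 or compound 4. As far as these compounds go, the unsubstituted amine at this carbon also remains open.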